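The compounds below may be only part of what the source reports. "The series", "measured", "known", "first", "only" and "open" are said of these compounds alone.

Compound 1 `Cc1ccc(N2CCn3c2n[nH]c(=O)c3=O)cc1`: 22% in a functional assay on T47D cells (Homo sapiens) for cytotoxicity, with a stated time of 72 h, tested at 50 ug/mL; a lower number here means a weaker effect, a higher number a stronger effect of the compound at the concentration tested
Compound 2 `Cc1ccccc1N1CCn2c1n[nH]c(=O)c2=O`: 0% in this assay
Compound 3 `N/N=C1\NCCN1c1ccccc1`: 0% in this assay

Among these three, compound 1 stands highest in this assay: compound 2 and compound 3 both sit beyond the scatter below it, at the same distance. Compound 4 `COc1ccc(N2CCn3c2n[nH]c(=O)c3=O)cc1` has not yet been measured in this assay. It keeps the core of compound 1 and differs from it in a single place: methoxy in place of methyl on an aromatic carbon. Going by the values given here, no step between two measured compounds touches this kind of exchange, so nothing measured here tells how large a move to expect. A step of this sort is expected to stay within the scatter, with no clear direction. For compound 4 the estimate is 18% (range 0% to 40%), an expected step of a number 4 percentage points lower from compound 1 to compound 4 (within the scatter).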

Compound 4, a percentage reported as inhibition, at one concentration (the size of the read-out at that concentration, not a potency): 21%
Compound 4: the middle estimate sits 3 percentage points below what was measured, within the range that was stated.
By their numbers in this assay, from the lowest: compounds 2 and 3 (each within the scatter of the next); then compounds 4 and 1 (each within the scatter of the next).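

In this assay, methoxy in place of methyl on this aromatic carbon, para to a large group, gives a number 1 percentage points lower from compound 1 to compound 4 (within the scatter). At this position, then, the added oxygen brings no readable difference, and the modest effect of compound 1 is kept in compound 4. Nothing available explains why this exchange leaves the read-out unmoved.

Still open, from the compounds shown here alone, is whether a group of another kind at the same carbon, such as an amine, a carboxylic acid or a longer chain, would shift the read-out beyond the scatter.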